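The compounds below may be only part of what the source reports. "The series", "measured", "known", "first", "only" and "open" are said of these compounds alone.

Compound 1 `CCCOC(=O)C1=C(C)NC(C)=C(C(=O)OCCC)C1c1csc(-c2ccc(Cl)cc2)n1`, compound 2 `CCCOC(=O)C1=C(C)NC(C)=C(C(=O)OCC)C1c1csc(-c2ccc(Cl)cc2)n1` and compound 3 `COC(=O)C1=C(C)NC(C)=C(C(=O)OC(C)(C)C)C1c1csc(-c2ccc(Cl)cc2)n1` share one core carrying two ester groups, and they differ only in the saturated chains attached to those esters. In an assay on isolated protein for antagonist activity at Voltage-dependent L-type calcium channel subunit alpha-1C (Cavia porcellus), with a stated time of 15 min (a lower number here means a stronger inhibitor, a higher number a weaker inhibitor), compound 1 gives 4800 nM, compound 2 gives 4090 nM, and compound 3 gives 46000 nM. Compound 2 and compound 1 differ in a single place, (methyl in place of hydrogen on a saturated chain carbon, two bonds along the chain from an oxygen next to a carbonyl group), and that change gave a 1.2-fold higher number from compound 2 to compound 1 (0.07 log units; within the scatter). Compound 3 has the highest number of the three, and its gap to both compound 1 and compound 2 lies beyond the scatter. How compound 3 and compound 2 differ is not broken down here: the two have the same atoms, joined differently.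

Compound 4 `CCOC(=O)C1=C(C)NC(C)=C(C(=O)OC(C)(C)C)C1c1csc(-c2ccc(Cl)cc2)n1` has not yet been measured in this assay. It relates to compound 3 much as compound 1 relates to compound 2, through (methyl in place of hydrogen on a saturated chain carbon bound to an oxygen next to a carbonyl group). The place is not identical, though: in the earlier pair the carbon sits two bonds along the chain from an oxygen next to a carbonyl group, whereas here it is bound to an oxygen next to a carbonyl group, so this is the same kind of change rather than the same change. Because the earlier step was a 1.2-fold higher number from compound 2 to compound 1 (0.07 log units; within the scatter), a small step is expected here as well, a 1.4-fold lower number from compound 3 to compound 4 (0.16 log units; within the scatter). Compound 4 is estimated to give about 32000 nM in this assay, with a likely range from 12000 nM to 85000 nM.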

Compound 4, half-maximal inhibitory concentration: 91000 nM
Compound 4: the middle estimate sits 2.8-fold (0.45 log units) below what was measured; the measured number lies above the stated range.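

Swapping a hydrogen for a methyl on a saturated ester chain gives a 2.0-fold higher number from compound 3 to compound 4 (0.30 log units; within the scatter), so this small change stays inside the usual noise on a second core as well, and the two cores agree as closely as this assay can tell: the same change on two cores in this assay, a 1.2-fold higher number (0.07 log units; within the scatter) from compound 2 to compound 1 and a 2.0-fold higher number (0.30 log units; within the scatter) from compound 3 to compound 4, 1.7-fold (0.23 log units) apart, within the scatter of two such steps. Within the data shown here, this does not prove that the methyl has no effect or that the two steps are identical, since only two pairs are compared and the methyl enters at a different carbon in each, two bonds along the chain from an oxygen next to a carbonyl group in one and bound to that oxygen in the other. The large step shown here comes with a different change, tert-butyl in place of propyl on an oxygen next to a carbonyl group, which gives a 22-fold higher number from compound 2 to compound 4 (1.35 log units; beyond the scatter), and that step shows that a small chain change cannot be taken as a guide to every ester change in this series.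

On these data alone, it remains open how the numbers would respond to an isopropyl ester, a longer chain or an ester chain ending in an amine. Whether the methyl step would also stay small on a core without tert-butyl or propyl esters is equally unsettled.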